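The source may report more compounds than this note shows. Statements on the series, on what has been measured and on what is new or still open speak of the compounds shown alone.

Measured so far: compound 1 `ClCc1cccc(Cn2cnc3ncnc(Cl)c32)c1` gives 15800 nM; compound 2 `ClCc1cccc(Cn2cnc3c(Cl)ncnc32)c1` gives 5750 nM; compound 3 `ClCc1cccc(Cn2cnc3c(Cl)nc(Cl)nc32)c1` gives 20000 nM.

All three were tested in a functional assay on OVCAR-4 cells (Homo sapiens) for cytotoxicity, read by sulforhodamine B assay, with a stated time of 48 h; a higher number here means a weaker inhibitor of growth, a lower number a stronger inhibitor of growth. Compound 1 and compound 2 share the same atoms joined differently; the difference between the two cores is not broken down here. Compound 3 differs from compound 2 by chloro in place of hydrogen on an aromatic carbon, and this change gave a 3.5-fold higher number from compound 2 to compound 3 (0.54 log units; beyond the scatter).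

Compound 4 `ClCc1cccc(Cn2cnc3nc(Cl)nc(Cl)c32)c1` has not yet been tested. It differs from compound 1 by chloro in place of hydrogen on an aromatic carbon, the same change seen from compound 2 to compound 3. Because that step was a 3.5-fold higher number from compound 2 to compound 3 (0.54 log units; beyond the scatter), a step of similar size and direction, a 2.5-fold higher number from compound 1 to compound 4 (0.40 log units; beyond the scatter), is expected here. Compound 4 is therefore estimated at 40000 nM, likely somewhere from 15000 nM to 100000 nM.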

Compound 4, concentration for total growth inhibition: 2950 nM
Beside the measured number, compound 4's estimate is 14-fold (1.13 log units) above it; the whole stated range lies above it.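

In this assay, placing a chloro group on the aromatic carbon between two ring nitrogen atoms gave a 5.4-fold lower number from compound 1 to compound 4 (0.73 log units; beyond the scatter). The effect of this change therefore cannot simply be carried from one core to the other, since it went in opposite directions on the two: the same change on two cores in this assay, a 3.5-fold higher number (0.54 log units; beyond the scatter) from compound 2 to compound 3 and a 5.4-fold lower number (0.73 log units; beyond the scatter) from compound 1 to compound 4, 19-fold (1.27 log units) apart, beyond the scatter of two such steps This shows that, among these four compounds, the outcome depends on the core, but two steps do not explain why or predict the result on any further core.

The compounds shown carry only hydrogen or chloro at this ring position, so it remains open how an amine or a methoxy group there would behave on either core. All four also keep the chloromethyl group, leaving open what a longer chain in its place would do.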